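The compounds below may be only part of what the source reports. "The series", "measured", "known", "first", "only" and "open" are said of these compounds alone.

Compound 1 `COc1ccc(-n2cc(-c3ccccc3)c(-c3ccc4c(c3)NC(=O)CO4)n2)cc1` gives 92.2% in a functional assay on DLD-1 cells (Homo sapiens) for cytotoxicity, read by colorimetric assay and MTT assay, with a stated time of 3 days, tested at 1 uM; on this read-out higher numbers stand for a weaker effect at the one concentration tested and lower numbers for a stronger effect; compound 2 `O=C1COc2ccc(-c3nn(-c4ccc(Br)cc4)cc3-c3ccccc3)cc2N1` gives 66.4%.

Within the data shown here, compound 2 stands lowest of the two, with compound 1 a number 25.8 percentage points lower from compound 1 to compound 2 (beyond the scatter) its only neighbour. Compound 3 `O=C1COc2ccc(-c3nn(-c4ccc(Cl)cc4)cc3-c3ccccc3)cc2N1` differs from compound 2 by chloro in place of bromo on an aromatic carbon. No measured step exchanges one halogen for another; the single step shown, bromo in place of methoxy, moved the number by a number 25.8 percentage points lower from compound 1 to compound 2 (beyond the scatter), which bears on it only loosely. Compound 3 is therefore expected to stay close to compound 2, with a step of a number 5.6 percentage points higher from compound 2 to compound 3 (within the scatter) at most, within or near the scatter. The estimate for compound 3 is 72%, ranging from 55% to 90%.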

Compound 3, a percentage reported as activity, at one concentration (the size of the read-out at that concentration, not a potency): 61.9%
The estimate for compound 3 lay 10.1 percentage points above the measured number; measured number inside the range.
By their numbers in this assay, from the lowest: compounds 3 and 2 (each within the scatter of the next); then compound 1.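

Within this assay, exchanging one halogen for the other at this place, 4-bromophenyl to 4-chlorophenyl, gives a number 4.5 percentage points lower from compound 2 to compound 3 (within the scatter), so bromo and chloro cannot be told apart here. Set against methoxy, chloro gives a number 30.3 percentage points lower from compound 1 to compound 3 (beyond the scatter), so the lower number seen with bromo now holds for a second halogen. Nothing available accounts for this separation of the two halogens from methoxy.

On these data alone, whether fluoro, an amine or a carboxylic acid at this place would fall with the halogens or with methoxy stays open. So does whether this order would hold at other concentrations.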